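The source may report more compounds than this note shows. Statements on the series, on what has been measured and on what is new or still open speak of the compounds shown alone.

Working notes on the series. Within the data shown here, compound 1 `O=c1[nH]c(=O)n([C@H]2C[C@H](O)[C@@H](CO)O2)cc1-c1cn(-c2cc(F)cc(F)c2)nn1` is the first reference point; in an ADME assay on HEL cells (Homo sapiens) for cytotoxicity, read by cell counting, with a stated time of 3 days (a higher number here means that more compound is tolerated, a lower number that less compound is tolerated), compound 1 gives 220000 nM. Compound 2 `CC(C)(C)c1ccc(-n2cc(-c3cn([C@H]4C[C@H](O)[C@@H](CO)O4)c(=O)[nH]c3=O)nn2)cc1` carries 4-(tert-butyl)phenyl in place of 3,5-difluorophenyl on an aromatic nitrogen, and in this assay compound 2 gives 230000 nM. The step of a 1.0-fold higher number from compound 1 to compound 2 (0.02 log units; within the scatter) lies within the scatter, so compound 2 and compound 1 stand at numbers that cannot be told apart on these two measurements; compound 2 holds the higher of the two figures only nominally.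

Compound 3 `O=c1[nH]c(=O)n([C@H]2C[C@H](O)[C@@H](CO)O2)cc1-c1cn(-c2ccc(Cl)cc2)nn1` is not yet measured. Relative to compound 2 the change is chloro in place of tert-butyl on an aromatic carbon. Among the measured compounds shown here, the only measured step that bears on it is the swap on the same aromatic ring from compound 1 to compound 2, a 1.0-fold higher number from compound 1 to compound 2 (0.02 log units; within the scatter), which did not move the number beyond the scatter. On that basis the expected step of a 1.0-fold lower number from compound 2 to compound 3 (0.02 log units; within the scatter) is none beyond the scatter. Compound 3 is therefore estimated at 220000 nM, with a range from 100000 nM to 450000 nM.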

Compound 3, minimum cytotoxic concentration: > 240000 nM
Compound 3: only a limit was reported; the forecaster's own chance of this, stated with the estimate: 20%; middle value at least 1.0-fold (0.03 log units) from the limit.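

In this assay compound 3 reaches a limit of the assay, > 240000 nM, and not a number. The steps are therefore floors only, an at least 1.0-fold higher number from compound 2 to compound 3 (0.01 log units; that floor lies within the scatter) and an at least 1.0-fold higher number from compound 1 to compound 3 (0.03 log units; that floor lies within the scatter): chloro in place of tert-butyl on an aromatic carbon, with one heavy atom entering for four, and 4-chlorophenyl in place of 3,5-difluorophenyl on an aromatic nitrogen, give no floor that separates compound 3 from compound 2 or compound 1. Going by these compounds, the real size of both steps stays unknown because the reading stops at a limit: the limit of > 240000 nM in this assay, at which 1 of the 3 values shown sits.

On these data alone, whether compound 3 truly differs from compound 1 and compound 2 remains open. Also open, as far as these compounds go, is how this assay responds when an amine or a carboxylic acid sits on the aromatic ring in place of chloro or tert-butyl.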